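This account rests on a few compounds, and the source may have more. Where it says the series, first, only, none or still open, it means among the compounds named here.

Measured so far:
- compound 1, `CCc1cc(-c2ccc(F)cc2)c(O)cc1OCCCOc1cccc(CCCCC(=O)N(C)C)c1CCC(=O)O`: 7.8 nM
- compound 2, `CCc1cc(-c2ccc(F)cc2)c(O)cc1OCCCOc1cccc(OC)c1CCC(=O)O`: 64 nM
- compound 3, `CCCc1c(OCCCOc2cc(O)c(-c3ccc(F)cc3)cc2CC)ccc2c1OC(C(=O)O)CC2`: 17 nM

In a functional assay for inhibition of leukotriene B4 receptor (Homo sapiens) (on this read-out higher numbers stand for weaker inhibition and lower numbers for stronger inhibition), compound 2 stands at the highest of the three numbers; compound 3 sits nearest with a lower number, and compound 1 furthest with the lowest of the three. Compound 4, `CCc1cc(-c2ccc(F)cc2)c(O)cc1OCCCOc1ccccc1CCC(=O)O`, has not yet been measured. It differs from compound 2 in one place: hydrogen in place of methoxy on an aromatic carbon. Within the data shown here, the one measured step that touches the same position is an 8.2-fold higher number from compound 1 to compound 2 (0.91 log units; beyond the scatter), in which a large group gave way to methoxy and the number rose. Among the measured compounds shown here, compound 4 now removes the methoxy altogether, and no measured pair shows what a bare hydrogen does at that carbon. The direction of the step in this assay is therefore uncertain; a further loss of some size seems somewhat more likely than a gain, but neither can be ruled out. For compound 4 the expected value is 110 nM, within a range from 30 nM to 400 nM, which corresponds to an expected step of a 1.7-fold higher number from compound 2 to compound 4 (0.24 log units; within the scatter).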

Compound 4, half-maximal inhibitory concentration: 31 nM
Beside the measured number, compound 4's estimate is 3.5-fold (0.55 log units) above it, and the stated range covers the measured number.
By their numbers in this assay, from the lowest: compound 1; then compounds 3 and 4 (each within the scatter of the next); then compound 2.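

In this assay, taking the methoxy off this aromatic carbon, ortho to the 2-carboxyethyl group, gives a 2.1-fold lower number from compound 2 to compound 4 (0.31 log units; beyond the scatter), so a bare hydrogen does better here than methoxy. The 4-(dimethylcarbamoyl)butyl group of compound 1 remains better than hydrogen, as a 4.0-fold higher number from compound 1 to compound 4 (0.60 log units; beyond the scatter) shows, which places hydrogen between the two groups and means the number does not rise or fall steadily with group size across compounds 1, 2 and 4. Nothing available explains this order.

The compounds shown leave open how a fluorine, an amine or a plain butyl chain would behave at this carbon. They therefore also leave open whether compound 1 owes its lower number to the length of its chain or to the dimethylcarbamoyl end.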